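Trifluoromethyl for chloro on the urea aryl ring

The source may hold more compounds than are shown below. What is called first, only, known or untested is meant among the compounds shown, and "the series" means these compounds.

Of the compounds shown here, three of the shared core have been measured in a functional assay on K562 cells (Homo sapiens) for inhibition, read by sulforhodamine B assay, with a stated time of 48 h; a lower number here means a stronger inhibitor of growth, a higher number a weaker inhibitor of growth. Compound 1 `COc1cc(-c2nn(-c3cccc(NC(=O)c4cccc(C(F)(F)F)c4)c3)cc2-c2ccncc2)ccc1Cl` gives 1400 nM. Compound 2 `COc1cc(-c2nn(-c3cccc(NC(=O)Nc4ccc(Cl)c(Cl)c4)c3)cc2-c2ccncc2)ccc1Cl` gives 890 nM, and the change in between reads a 1.6-fold lower number from compound 1 to compound 2 (0.20 log units; within the scatter). Compound 3 `O=C(Nc1cccc(-n2cc(-c3ccncc3)c(-c3ccc(Cl)c(O)c3)n2)c1)Nc1ccc(Cl)c(Cl)c1` gives 1410 nM, with the change from compound 2 reading a 1.6-fold higher number from compound 2 to compound 3 (0.20 log units; within the scatter). Compound 3 thus has the highest number of the three, but its gaps to compound 1 and to compound 2 are both within the scatter, so no order among them can be claimed.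

Compound 4 `O=C(Nc1cccc(-n2cc(-c3ccncc3)c(-c3ccc(Cl)c(O)c3)n2)c1)Nc1ccc(Cl)c(C(F)(F)F)c1` is not yet measured. It differs from compound 3 by trifluoromethyl in place of chloro on an aromatic carbon. Neither measured step bears directly on this exchange: one moves a carbonyl substituent to an amino substituent, the other removes a methyl from an oxygen. Among the measured compounds shown here, with no comparable step in hand, the expectation for compound 4 is a step of a 1.2-fold lower number from compound 3 to compound 4 (0.07 log units; within the scatter), not beyond the scatter. The estimate for compound 4 in this assay is therefore 1200 nM, expected within the range 450 nM to 3500 nM.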

Compound 4, concentration for 50% growth inhibition: 921 nM
Compound 4: middle estimate off by 1.3-fold (0.11 log units), on the high side, and the stated range covers the measured number.
By their numbers in this assay, from the lowest: compounds 2, 4, 1 and 3 (each within the scatter of the next).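

In this assay, trifluoromethyl in place of chloro, ortho to a chloro group and meta to a large group, gives a 1.5-fold lower number from compound 3 to compound 4 (0.18 log units; within the scatter). Among the compounds shown here, this is the first look at this position of the aryl ring: a group of 4 heavy atoms stands in place of one of 1 heavy atom, with no step beyond the scatter, whereas the earlier steps changed the group on the carbonyl carbon and the methyl on the oxygen. No measurement at hand bears on the reason for this outcome.

Going by these compounds, whether a nitrile, an amine or a carboxylic acid at this position would give a step beyond the scatter stays open. Also open, on these data alone, is whether the same exchange reads alike with the methyl on the oxygen, as in compound 2.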